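The source may hold more compounds than are shown below. What is called first, only, known or untested is meant among the compounds shown, and "the series" means these compounds.

Measured so far in a physicochemical assay for lipophilicity, using the shake flask method; a higher number here means a more lipophilic compound, a lower number a more polar compound:
- compound 1 `C[C@H](Oc1ccc2ncc(/C=C/C(N)=O)c(C3CC3)c2c1)c1c(Cl)ccc(F)c1Cl`: > 5.5, which is a limit of the assay and not a number
- compound 2 `C[C@H](Oc1ccc2ncc(/C=C/C(=O)O)c(C3CC3)c2c1)c1c(Cl)ccc(F)c1Cl`: 4.1

Among the compounds with values here, compound 2, at 4.1, holds the only true number in this assay so far. Compound 3 `C[C@H](Oc1ccc2ncc(S(=O)(=O)CC(=O)O)c(C3CC3)c2c1)c1c(Cl)ccc(F)c1Cl` carries (carboxymethyl)sulfonyl in place of 2-carboxyethenyl on an aromatic carbon, ortho to a cyclopropyl group ((carboxymethyl)sulfonyl in place of 2-carboxyethenyl on an aromatic carbon). Within the data shown here, no measured step makes this same change. Among the measured compounds shown here, the one step available is a number at least 1.40 log units lower from compound 1 to compound 2 (beyond the scatter), with hydroxy in place of amino on a carbonyl carbon. It is large, but it is only a loose guide, since its full size is hidden by the limit and it alters the end of the chain, whereas here the carboxy end stays and the link to the core changes. Starting from compound 2 at 4.1, a moderate fall is expected, given the added hydrogen-bond acceptors in compound 3. The expected step is a number 1.10 log units lower from compound 2 to compound 3 (beyond the scatter), which is a downward estimate. For compound 3 the estimated value is 3, with an expected range from 2.2 to 3.7.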

Compound 3, distribution coefficient: 2.5
Compound 3: the middle estimate sits 0.50 log units above what was measured; measured number inside the range.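

In this assay, the earlier step changed only the end of the chain, whereas this result shows that the number also moves when the carboxy end stays and the link to the core changes: a number 1.60 log units lower from compound 2 to compound 3 (beyond the scatter). This fall comes even though (carboxymethyl)sulfonyl has 7 heavy atoms against 5 in 2-carboxyethenyl, so at this position, ortho to a cyclopropyl group, added size alone does not raise the number. Replacing 2-carbamoylethenyl at the same place gives a number at least 3.00 log units lower from compound 1 to compound 3 (beyond the scatter), but this size is only a bound, as compound 1 carries a limit of the assay and not a number: the limit of > 5.5 in this assay, at which 1 of the 3 values shown sits.

The compounds shown leave open how much of the fall belongs to the sulfonyl group and how much to the change in the chain, as the two arrive together in compound 3. A methylsulfonyl group with no carboxylic acid, or a longer chain between the sulfonyl group and the carboxylic acid, would help pull these two parts apart.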